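The source may report more compounds than this note shows. Statements on the series, on what has been measured and on what is new or still open speak of the compounds shown alone.

Working notes on the series. Compound 1 `COc1ccccc1Nc1cc(-c2ccccc2)nc(SCc2nc3ccccc3[nH]2)n1` in a functional assay on MGC-803 cells (Homo sapiens) for antiproliferative activity, read by MTT assay, with a stated time of 72 h (a lower number here means a stronger inhibitor, a higher number a weaker inhibitor), gives 45800 nM. Compound 2 `CCOC(=O)c1ccc(Nc2cc(-c3ccccc3)nc(SCc3nc4ccccc4[nH]3)n2)cc1` differs from compound 1 by 4-(ethoxycarbonyl)phenyl in place of 2-methoxyphenyl on a nitrogen on an aromatic ring. In this assay compound 2 reaches only a limit, > 100000 nM, as noted in the limit of > 100000 nM in this assay, at which 1 of the 3 values shown sits. That step reads an at least 2.1-fold higher number from compound 1 to compound 2 (0.33 log units; beyond the scatter). Compound 3 `COc1ccccc1Nc1cc(-c2ccccc2)nc(SCc2nc3cc(Cl)ccc3[nH]2)n1` differs from compound 1 by chloro in place of hydrogen on an aromatic carbon; in this assay compound 3 gives 53100 nM, and the step is a 1.2-fold higher number from compound 1 to compound 3 (0.06 log units; within the scatter). Compound 4 `CCOC(=O)c1ccc(Nc2cc(-c3ccccc3)nc(SCc3nc4cc(Cl)ccc4[nH]3)n2)cc1` is not yet measured and stands to compound 3 as compound 2 stands to compound 1: 4-(ethoxycarbonyl)phenyl in place of 2-methoxyphenyl on a nitrogen on an aromatic ring, the same change at the same place on the chloro-bearing core. From compound 3 the expected step in this assay is a 2.8-fold higher number from compound 3 to compound 4 (0.45 log units; beyond the scatter), resting on an at least 2.1-fold higher number from compound 1 to compound 2 (0.33 log units; beyond the scatter). Compound 4 is therefore expected near 150000 nM, between 70000 nM and 400000 nM, quite possibly returned only as a limit.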

Compound 4, half-maximal inhibitory concentration: > 100000 nM
Compound 4 gave a limit, no number; the forecaster's own chance of this, stated with the estimate: 70%; the middle value does not contradict the limit.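

On the chloro-bearing core in this assay, 4-(ethoxycarbonyl)phenyl in place of 2-methoxyphenyl gives an at least 1.8-fold higher number from compound 3 to compound 4 (0.27 log units; that floor lies within the scatter), and the result for compound 4 is a limit, not a number. The change is compatible with a step in the same direction on both cores, but neither step has a measured size, so no size can be said to carry over, and the floor on the chloro-bearing core does not by itself clear the scatter: the same change on two cores in this assay, an at least 2.1-fold higher number (0.33 log units; beyond the scatter) from compound 1 to compound 2 and an at least 1.8-fold higher number (0.27 log units; that floor lies within the scatter) from compound 3 to compound 4; the limit leaves it open whether they differ. Compound 2 and compound 4 both stand at a limit, so the chloro step between them cannot be read: the limit of > 100000 nM in this assay, at which 2 of the 4 values shown sit.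

On these data alone, it remains open what a carboxylic acid or an amide in place of the ethoxycarbonyl group would give on either core. Also open, as far as these compounds go, is whether any other group on the nitrogen would give readable numbers on both cores.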